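The source may hold more compounds than are shown below. What is called first, only, known or untested is meant among the compounds shown, and "the series" means these compounds.

Measured compounds and their values:
- Compound 1, `CCOC(=O)/C=C1/C(=O)Nc2ccccc21`: 81.4%
- Compound 2, `CC(C)(C)OC(=O)/C=C1/C(=O)Nc2ccccc21`: 83.3%
- Compound 3, `CN1C(=O)/C(=C/C(=O)OC(C)(C)C)c2ccccc21`: 81.9%

All three were tested in a functional assay on SAOS-2 cells (Homo sapiens) for inhibition, read by CCK-8 assay, with a stated time of 72 h, tested at 20 uM; a lower number here means less inhibition of growth, a higher number more inhibition of growth at the concentration tested. Compound 2 gives the highest of the three numbers, but the two measured steps, a number 1.9 percentage points higher from compound 1 to compound 2 (within the scatter) and a number 1.4 percentage points lower from compound 2 to compound 3 (within the scatter), both fall within the scatter, so the three compounds cannot really be told apart on these numbers.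

Compound 4, `CC(C)c1ccc2c(c1)/C(=C\C(=O)OC(C)(C)C)C(=O)N2`, differs from compound 2 by isopropyl in place of hydrogen on an aromatic carbon. Neither measured step touches the aromatic ring: one exchanges the ester group, the other adds a methyl to the ring nitrogen, and each left the number essentially where it was. Among the compounds with values here, there is no measured change on the aromatic ring at all, so the only guidance is that small changes elsewhere on this shared core have so far made no difference beyond the scatter. The step from compound 2 to compound 4 is therefore expected to be a number 1.3 percentage points lower from compound 2 to compound 4 (within the scatter), which is expected to remain within the scatter. Compound 4 is expected to give 82%, with a range from 70% to 92%.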

Compound 4, percent growth inhibition at one concentration: 82.8%
Beside the measured number, compound 4's estimate is 0.8 percentage points below it, and the stated range covers the measured number.
By their numbers in this assay, from the lowest: compounds 1, 3, 4 and 2 (each within the scatter of the next).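

Within the data shown here, the change to isopropyl in place of hydrogen on an aromatic carbon gives a number 0.5 percentage points lower from compound 2 to compound 4 (within the scatter) in this assay, and it is the first measured change on the aromatic ring of the shared core. It shows that this carbon, para to a fused ring and meta to a fused ring, can carry a branched group of 3 heavy atoms without a shift that can be told from the scatter. Nothing measured here bears on the reason for this result.

As far as these compounds go, whether an amine, a carboxylic acid or a longer chain on this same carbon would also leave the number in place remains open. From the compounds shown here alone, with all four compounds within the scatter of the next at a single concentration, any real differences among them also remain open.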